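Inverting a single ring stereocentre: compound 3 to compound 4

The source may hold more compounds than are shown below. What is called first, only, known or untested is meant among the compounds shown, and "the series" means these compounds.

Compound 3 `O=C(O)[C@H]1NC[C@@H](O)[C@@H](O)[C@@H]1O` gives 3.8% in an assay for inhibition of alpha-N-acetylgalactosaminidase (Gallus gallus), tested at 1000 uM (on this read-out lower numbers stand for less inhibition and higher numbers for more inhibition at the one concentration tested (going by the name of the read-out)), the second highest of the three numbers shown; compound 1 `O=C(O)[C@H]1NC[C@@H](O)[C@H](O)[C@H]1O` gives 4.2% and compound 2 `O=C(O)[C@H]1NC[C@H](O)[C@@H](O)[C@@H]1O` gives 0.2%, so all three lie within the scatter of one another. Compound 4 `O=C(O)[C@@H]1NC[C@@H](O)[C@@H](O)[C@@H]1O` differs from compound 3 in this way: the two compounds have the same atoms and bonds and differ only in configuration as drawn: 1 of 4 stereo elements differ; a stereocentre at a saturated ring carbon is drawn S in compound 3 and R in compound 4. The comparable changes of configuration already measured, a number 4 percentage points lower from compound 1 to compound 2 (within the scatter), a number 0.4 percentage points lower from compound 1 to compound 3 (within the scatter) and a number 3.6 percentage points higher from compound 2 to compound 3 (within the scatter), all stayed within the scatter, even for the largest of these configurational changes (the fact that compounds 1 and 2 differ only in the configuration as drawn). A single inversion is therefore expected to produce no step beyond the scatter, a number 0.8 percentage points lower from compound 3 to compound 4 (within the scatter). Compound 4 is expected to give 3%, between -3% and 10%.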

Compound 4, a percentage reported as inhibition, at one concentration (the size of the read-out at that concentration, not a potency): 7.2%
Compound 4: the middle estimate sits 4.2 percentage points below what was measured, within the range that was stated.
By their numbers in this assay, from the lowest: compounds 2, 3, 1 and 4 (each within the scatter of the next).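

In this assay, compounds 1, 2 and 3 share one drawing at this saturated ring carbon, and inverting it alone gives a number 3.4 percentage points higher from compound 3 to compound 4 (within the scatter). Taken with changes at other stereocentres, the inversion also stays within the scatter, with a number 7 percentage points higher from compound 2 to compound 4 (within the scatter) and a number 3 percentage points higher from compound 1 to compound 4 (within the scatter). No configuration shown therefore stands apart from the others, and this stereocentre joins the others in producing no step beyond the scatter.

The compounds leave open whether a hydroxymethyl group or an amide in place of the carboxylic acid would change the read-out. They also leave open what a longer chain on the nitrogen would do.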